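Working notes: compound 4 against the ester series

The source may hold more compounds than are shown below. What is called first, only, known or untested is meant among the compounds shown, and "the series" means these compounds.

Of the compounds shown here, three of the shared core have been measured in a functional assay on A-375 cells (Homo sapiens) for cytotoxicity, read by MTT assay; on this read-out higher numbers stand for weaker inhibition and lower numbers for stronger inhibition. Compound 1 `COc1ccc(/C=C/C(=O)c2ccc(OC)c3c2OC(C)(C)C=C3)cc1OC(=O)C(C)C` gives 310 nM; compound 2 `COc1ccc(/C=C/C(=O)c2ccc(OC)c3c2OC(C)(C)C=C3)cc1OC(=O)C1CC1` gives 380 nM; compound 3 `COc1cccc(C(=O)Oc2cc(/C=C/C(=O)c3ccc(OC)c4c3OC(C)(C)C=C4)ccc2OC)c1` gives 800 nM. Compound 1 holds the lowest of the three numbers, with compound 2 nearest and compound 3 furthest, although the gap to compound 2 lies within the scatter.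

Compound 4 `COc1ccc(/C=C/C(=O)c2ccc(OC)c3c2OC(C)(C)C=C3)cc1OS(=O)(=O)c1ccc(C)cc1` has not been measured. Its difference from compound 1: (4-methylphenyl)sulfonyl in place of isopropylcarbonyl on an oxygen on an aromatic ring.

Within the data shown here, two measured steps bear on this change. a 1.2-fold higher number from compound 1 to compound 2 (0.09 log units; within the scatter) exchanges cyclopropyl for isopropyl and stays within the scatter. a 2.6-fold higher number from compound 1 to compound 3 (0.41 log units; beyond the scatter) puts 3-methoxyphenyl on the carbonyl carbon and gives a modest rise; a 2.1-fold higher number from compound 2 to compound 3 (0.32 log units; beyond the scatter) agrees with it. Among the measured compounds shown here, the change to compound 4 also brings in a six-membered aromatic ring of carbon only, but attached through a sulfonyl rather than a carbonyl, so no measured step covers it directly. The step to compound 3 is the nearest guide, so a modest rise in this assay is expected, with wider uncertainty than within the ester pairs.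

Compound 4 is therefore expected at 750 nM, in the range 300 nM to 2000 nM. The expected step is a 2.4-fold higher number from compound 1 to compound 4 (0.38 log units; beyond the scatter).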

Compound 4, half-maximal inhibitory concentration: 2400 nM
The estimate for compound 4 lay 3.2-fold (0.51 log units) below the measured number; measured number outside the range, above it.
By their numbers in this assay, from the lowest: compounds 1 and 2 (each within the scatter of the next); then compound 3; then compound 4.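

In this assay, the groups on the carbonyl carbon in compounds 1 to 3 span a narrower range than the change to (4-methylphenyl)sulfonyl on the oxygen on an aromatic ring, which gives a 7.7-fold higher number from compound 1 to compound 4 (0.89 log units; beyond the scatter) and a 6.3-fold higher number from compound 2 to compound 4 (0.80 log units; beyond the scatter), the two largest steps in the series. Against the group that also carries a six-membered aromatic ring of carbon only, the change still gives a 3.0-fold higher number from compound 3 to compound 4 (0.48 log units; beyond the scatter), so the presence of such a ring does not by itself set the number at this position. No measured information is available to explain the rise.

The step from compound 3 to compound 4 changes both the carbonyl to a sulfonyl and the substituent on the ring, so the contribution of each stays unresolved. A (4-methylphenyl)carbonyl group on the same oxygen would isolate the sulfonyl exchange, while a methylsulfonyl group would show whether the rise persists without the aromatic ring.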